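Aryl variation at the benzylamine end of a sulfonamide series

The source may hold more compounds than are shown below. What is called first, only, known or untested is meant among the compounds shown, and "the series" means these compounds.

Measured so far:
compound 1, `O=S(=O)(NCCCCNCc1ccc(Br)cc1)c1cc(C(F)(F)F)cc(C(F)(F)F)c1`, 2100 nM
compound 2, `COc1cccc(CNCCCNS(=O)(=O)c2cc(C(F)(F)F)cc(C(F)(F)F)c2)c1`, 1600 nM
compound 3, `O=S(=O)(NCCCNCc1ccc(-c2ccccc2)cc1)c1cc(C(F)(F)F)cc(C(F)(F)F)c1`, 2600 nM

Three compounds share the same bis(trifluoromethyl)phenylsulfonamide core joined through a short chain to a benzylamine, and all were run in a functional assay on A2780 cells (Homo sapiens) for inhibition, read by MTT assay, with a stated time of 72 h; a lower number here means a stronger inhibitor of growth, a higher number a weaker inhibitor of growth. Compound 2 sits alongside compound 1 and compound 3 in this assay: the gaps to both are within the scatter, so nothing separates the three.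

Compound 4, `O=S(=O)(NCCCNCc1ccc(Cl)c(C(F)(F)F)c1)c1cc(C(F)(F)F)cc(C(F)(F)F)c1`, has not yet been measured. It differs from compound 2 by 4-chloro-3-(trifluoromethyl)phenyl in place of 3-methoxyphenyl on a saturated chain carbon bound to an amine nitrogen.

The step that bears on this is the one at the same end of the molecule, a 1.3-fold lower number from compound 1 to compound 2 (0.12 log units; within the scatter), which swapped one aryl substituent pattern for another without a change beyond the scatter. Compound 3, carrying a biphenyl there, also gives a number close to compound 2. On that basis no step beyond the scatter is expected for a 1.1-fold higher number from compound 2 to compound 4 (0.05 log units; within the scatter). Compound 4 is therefore estimated at 1800 nM, within a range of 900 nM to 3600 nM.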

Compound 4, concentration for 50% growth inhibition: 5900 nM
Compound 4: the middle estimate sits 3.3-fold (0.52 log units) below what was measured, outside the stated range (above it).
By their numbers in this assay, from the lowest: compounds 2, 1 and 3 (each within the scatter of the next); then compound 4.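

In this assay, 4-chloro-3-(trifluoromethyl)phenyl in place of 3-methoxyphenyl on a saturated chain carbon bound to an amine nitrogen gives a 3.7-fold higher number from compound 2 to compound 4 (0.57 log units; beyond the scatter), a modest step but the first in the series beyond the scatter. The aryl group at this position is therefore not freely interchangeable, which a 1.3-fold lower number from compound 1 to compound 2 (0.12 log units; within the scatter) had not revealed. Nothing measured here offers an explanation for the step.

The change removes methoxy and introduces chloro and trifluoromethyl together, so the compounds shown do not assign the step to any one of these groups; an aryl group carrying chloro alone or trifluoromethyl alone would separate them. Also open, on these data alone, is how a carboxylic acid or an amide on the aryl group would read in this assay.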